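The source may hold more compounds than are shown below. What is called first, only, known or untested is meant among the compounds shown, and "the series" means these compounds.

Within the data shown here, compound 2 `Cc1oc2c([C@H]3CCN(C)C[C@H]3O)c(O)cc(O)c2c(=O)c1C(O)c1ccccc1Br` is the weaker of the two compounds measured so far: in a functional assay on MIA PaCa-2 cells (Homo sapiens) for inhibition, read by MTT assay, with a stated time of 48 h, tested at 10 uM (a lower number here means less inhibition of growth, a higher number more inhibition of growth at the concentration tested), compound 2 gives 10%, while compound 1 `Cc1cc(=O)c2c(O)c(CN3CCC(N4CCCCC4)CC3)c(O)c([C@H]3CCN(C)C[C@H]3O)c2o1` gives 23%, a gap beyond the usual scatter. Compound 3 `Cc1oc2c([C@H]3CCN(C)C[C@H]3O)c(O)cc(O)c2c(=O)c1C(O)c1ccc(F)cc1` differs from compound 2 by 4-fluorophenyl in place of 2-bromophenyl on a saturated chain carbon bound to an aromatic carbon and an oxygen on a saturated carbon. Among the measured compounds shown here, no pair of measured compounds shares this change, so nothing measured shows how it acts. Both measured values are modest, and compound 3 is expected to stay close to compound 2. The expected step is a number 2 percentage points higher from compound 2 to compound 3 (within the scatter), within the scatter. For compound 3 the estimate is 12%, with a range from 2% to 25%.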

Compound 3, percent growth inhibition at one concentration: 17%
Compound 3: the middle estimate sits 5 percentage points below what was measured, within the range that was stated.
By their numbers in this assay, from the lowest: compounds 2, 3 and 1 (each within the scatter of the next, the first and the last beyond it).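

In this assay, among these compounds, the first measured change at this position, 4-fluorophenyl in place of 2-bromophenyl on a saturated chain carbon bound to an aromatic carbon and an oxygen on a saturated carbon, gives a number 7 percentage points higher from compound 2 to compound 3 (within the scatter) and so does not separate the two groups. Nothing at hand explains this step. From the compounds shown here alone, this single change alters both the halogen and its place on the ring, so the effect of each alone remains unknown. Also open, going by these compounds, is what a different group here, such as a carboxylic acid or an amine, would give.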